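Notes on the step from compound 3 to compound 4

This account rests on a few compounds, and the source may have more. Where it says the series, first, only, none or still open, it means among the compounds named here.

Compound 3 `CCN(CC)c1ccc2cc(C(=O)c3ccc(N4CCN(C(=O)CN5CCN(Cc6ccc(/C=C/C(=O)OC)cc6)CC5)CC4)cc3)oc2c1` gives the lowest number of the three measured in a functional assay on A549 cells (Homo sapiens) for cytotoxicity, read by MTT assay, with a stated time of 48 h (on this read-out lower numbers stand for stronger inhibition and higher numbers for weaker inhibition), at 2810 nM. Compound 1 `CCN(CC)c1ccc2cc(C(=O)c3ccc(N4CCN(C(=O)CN5CCN(C(=O)/C=C/c6ccccc6)CC5)CC4)cc3)oc2c1` gives 9450 nM and compound 2 `CCN(CC)c1ccc2cc(C(=O)c3ccc(N4CCN(C(=O)CN5CCN(S(=O)(=O)C6CC6)CC5)CC4)cc3)oc2c1` gives 17300 nM in this assay. For the measured compounds named here, the one single-place step measured, a 1.8-fold higher number from compound 1 to compound 2 (0.26 log units; within the scatter), sits on an amine nitrogen in a ring and does not touch the place changed here. Compound 4 `CCN(CC)c1ccc2cc(C(=O)c3ccc(N4CCN(C(=O)CN5CCN(CC(C)=O)CC5)CC4)cc3)oc2c1` differs from compound 3 by acetyl in place of 4-(2-(methoxycarbonyl)ethenyl)phenyl on a saturated chain carbon bound to an amine nitrogen in a ring. Going by the values given here, no measured step bears on this change directly. Since compound 1 at 9450 nM and compound 2 at 17300 nM both sit higher than compound 3, compound 4 is expected near those numbers, at 9000 nM, between 3000 nM and 25000 nM, an expected step of a 3.2-fold higher number from compound 3 to compound 4 (0.51 log units; beyond the scatter).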

Compound 4, half-maximal inhibitory concentration: 8920 nM
Compound 4: middle estimate off by 1.0-fold (0.00 log units), on the high side; the range from low to high includes it.
By their numbers in this assay, from the lowest: compound 3; then compounds 4, 1 and 2 (each within the scatter of the next).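

Acetyl in place of 4-(2-(methoxycarbonyl)ethenyl)phenyl on a saturated chain carbon bound to an amine nitrogen in a ring gives a 3.2-fold higher number from compound 3 to compound 4 (0.50 log units; beyond the scatter) in this assay, the first measured change at this place. The other two steps, a 1.9-fold lower number from compound 2 to compound 4 (0.29 log units; within the scatter) and a 1.1-fold lower number from compound 1 to compound 4 (0.03 log units; within the scatter), stay within the scatter, so only compound 3 stands apart among these compounds. Nothing available gives a cause for this difference. Going by these compounds, whether the lower number of compound 3 depends on the phenyl ring, the ethenyl link or the methyl ester remains open. An unsubstituted benzyl group or the corresponding carboxylic acid at this place would help separate these parts.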